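A few compounds are considered here, and "the series" means these few. Any claim that something is new, unique, unknown or untested is made for them only; others in the source may bear on it.

Compound 1 `Cc1ccc(-c2ccccc2OC(C)C2=NCCN2)cc1` is the compound this account starts from. Within the data shown here, in an assay on CHO cells for displacement of a labelled ligand from Alpha-2B adrenergic receptor (Homo sapiens) (on this read-out higher numbers stand for weaker inhibition and lower numbers for stronger inhibition), compound 1 gives 398 nM, the lowest number among the three compounds measured so far, and so the strongest inhibition of the set. Compound 3 `CC(Oc1ccccc1-c1ccccc1[N+](=O)[O-])C1=NCCN1` carries a nitro group instead of the methylphenyl and gives 1550 nM, a higher number than compound 1 by more than the usual scatter. Compound 2 `CC(Oc1ccccc1-c1ccccc1)C1=NCCO1`, which has an oxazoline in place of the imidazoline and no substituent on the second ring, gives 10000 nM, a much higher number again.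

The step under consideration leads to compound 4 `CC(Oc1ccccc1-c1ccc(O)cc1)C1=NCCN1`. The change is hydroxy in place of methyl on an aromatic carbon. Among the measured compounds shown here, no measured pair in this set shows such a swap, so there is no step in this assay to lean on. A polar group takes the place of a small carbon group on the outer ring, and a modest loss of inhibition, or no change beyond the scatter, seems the most likely outcome.

Compound 4 is therefore expected to land at 630 nM, with a range from 160 nM to 2500 nM. This expectation corresponds to a step of a 1.6-fold higher number from compound 1 to compound 4 (0.20 log units; within the scatter) in this assay.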

Compound 4, inhibition constant: 813 nM
The estimate for compound 4 lay 1.3-fold (0.11 log units) below the measured number; measured number inside the range.
By their numbers in this assay, from the lowest: compound 1; then compounds 4 and 3 (each within the scatter of the next); then compound 2.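

In this assay, among these compounds, the earlier compounds offered no pair differing in one place, and this result supplies the first: placing a hydroxy instead of a methyl on an aromatic carbon, para to a large group, gives a 2.0-fold higher number from compound 1 to compound 4 (0.31 log units; beyond the scatter). The step is modest but beyond the scatter, so at this position the hydroxy, which brings a hydrogen-bond donor and a hydrogen-bond acceptor that the methyl lacks, weakens inhibition without abolishing it. No other measurement here bears on this step, so the reason for the change remains unknown.

A single pair cannot show whether this loss is particular to the hydroxy or would follow from replacing the methyl with other groups. Going by these compounds, how a methoxy, an amine or a fluorine at the same place would compare with compound 1 remains open, as does whether the same swap from 4-methylphenyl to 4-hydroxyphenyl would give a step of similar size on a core carrying an oxazoline instead of an imidazoline.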